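Amide series: compound 3 to compound 4

The source may hold more compounds than are shown below. What is called first, only, known or untested is meant among the compounds shown, and "the series" means these compounds.

Measured in an ADME assay on microsomes from liver (Mus musculus) for metabolic stability, read by LC-MS, with a stated time of 30 min, tested at 1 uM; a higher number here means that more of the compound is left, a lower number that less of the compound is left:
- compound 1 `O=C(NCc1ccc(S(=O)(=O)c2ccccc2)cc1)c1cc2ncccc2s1`: 1.6%
- compound 2 `O=C(NCc1ccc(S(=O)(=O)N2CCCCC2)cc1)c1cc2cnccc2s1`: "below limit of detection" (no number reported)
- compound 3 `O=C(NCc1ccc(S(=O)(=O)N2CCCCC2)cc1)c1ccc2nc[nH]c2c1`: 16%

Of the two numeric results, compound 3 stands highest at 16%. Compound 1 gives 1.6%, and the gap between these two results lies beyond the scatter. Compound 4 `O=C(NCc1ccc(S(=O)(=O)N2CCCCC2)cc1)c1cc2ccncc2o1` carries a group of 9 heavy atoms (7 carbon, 1 nitrogen, 1 oxygen; one five-membered aromatic ring with 1 hetero atom, one six-membered aromatic ring with 1 hetero atom) in place of a group of 9 heavy atoms (7 carbon, 2 nitrogen; one five-membered aromatic ring with 2 hetero atoms, one six-membered aromatic ring of carbon only), on a carbonyl carbon. For the measured compounds named here, no measured pair isolates this exchange. Compound 1, at 1.6%, also has a five-membered aromatic ring with 1 hetero atom and a six-membered aromatic ring with 1 hetero atom on its carbonyl carbon. Compound 2 has the same kind of ring pair, and no number was reported for it. A fall is therefore expected, with a number 11 percentage points lower from compound 3 to compound 4 (beyond the scatter) as the estimated step. The estimate for compound 4 is 5%, with an expected range of 0.5% to 18%.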

Compound 4, percent of the compound remaining: 0.14%
Estimate against measurement, compound 4: 4.9 percentage points above, and the stated range ends above it.
By their numbers in this assay, from the lowest: compounds 4 and 1 (each within the scatter of the next); then compound 3.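

At the place on the carbonyl carbon, replacing 1H-benzimidazol-6-yl with the ring pair carrying one hetero atom in each ring gives a number 15.9 percentage points lower from compound 3 to compound 4 (beyond the scatter) in this assay with the rest of the molecule unchanged. For the compounds shown here, this is the first single-place step, and it goes with a change from 1 hydrogen-bond donor to 0 and from 1 hydrogen-bond acceptor to 2. No measurement bearing on the cause of the step is available.

Which of the differences between the two groups matters remains open. So does how a 1H-indazol-6-yl group on the same carbonyl carbon would compare with 1H-benzimidazol-6-yl.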